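The source may hold more compounds than are shown below. What is called first, only, known or untested is meant among the compounds shown, and "the series" means these compounds.

Compound 1 `COc1cc(O)cc(O)c1C(=O)/C=C/c1ccccc1Br` is tested in a toxicity assay on cells (Macrophage, Mus musculus, strain BALB/c) for cytotoxicity, read by MTT assay (on this read-out higher numbers stand for weaker inhibition and lower numbers for stronger inhibition), where compound 1 gives 14600 nM. Two companions share the same broad layout. Compound 2 `C=CCOc1cc(OC)c(C(=O)/C=C/Cc2ccccc2)c(OCC=C)c1` gives 14800 nM in this assay, and compound 3 `C=CCOc1cc(OC)c(C(=O)/C=C/c2cccc(OC)c2)c(OCC=C)c1` gives 13100 nM. All three numbers fall within the usual scatter of one another, so compound 1 cannot be set apart from compound 2 or compound 3.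

Within the data shown here, the only measured step, a 1.1-fold lower number from compound 2 to compound 3 (0.05 log units; within the scatter), swaps the group on the double-bonded chain carbon and leaves the number essentially unchanged. Compound 4 `COc1cc(O)cc(O)c1C(=O)/C=C/c1ccc(C)cc1` arises from compound 1 by a comparable swap at the same place: 4-methylphenyl in place of 2-bromophenyl on a double-bonded chain carbon bound to a double-bonded chain carbon. With that precedent, no movement beyond the scatter is expected, no change at the digits printed from compound 1 to compound 4 (within the scatter). Compound 4 is therefore estimated at 14600 nM, with a plausible range from 7000 nM to 30000 nM.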

Compound 4, half-maximal inhibitory concentration: 16500 nM
Compound 4: middle estimate off by 1.1-fold (0.05 log units), on the low side, and the stated range covers the measured number.
By their numbers in this assay, from the lowest: compounds 3, 1, 2 and 4 (each within the scatter of the next).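

On the core of compound 1, 4-methylphenyl in place of 2-bromophenyl gives a 1.1-fold higher number from compound 1 to compound 4 (0.05 log units; within the scatter) in this assay. Among these compounds, the earlier step at this place was on the different core of compound 2, so this is the first evidence that the same place on the core of compound 1 can also lose its bromine and gain a methyl group without a change beyond the scatter. No available measurement offers an explanation for this result. As far as these compounds go, whether an amine or a carboxylic acid at this place would move the number beyond the scatter remains open.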